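A few compounds are considered here, and "the series" means these few. Any claim that something is new, unique, unknown or untested is made for them only; others in the source may bear on it.

Compound 1 `CCn1c(C(=O)NCC(=O)OC)ccc1C(CC)(CC)c1ccc(OCS(=O)(=O)c2ccccc2)c(C)c1`: in a functional assay on MCF7 cells (Homo sapiens) for antiproliferative activity, read by MTT assay, with a stated time of 24 h (a higher number here means a weaker inhibitor, a lower number a stronger inhibitor), compound 1 gives > 50000 nM, which is a limit of the assay and not a number.
Compound 2 `CCn1c(C(=O)NCCC(=O)OC)ccc1C(CC)(CC)c1ccc(OCS(=O)(=O)c2ccccc2)c(C)c1`: compound 2 gives > 50000 nM, again a limit.
Compound 3 `CCn1c(C(=O)N[C@@H](C)CO)ccc1C(CC)(CC)c1ccc(OCS(=O)(=O)c2ccccc2)c(C)c1`: compound 3 gives 10800 nM.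

Among the measured compounds shown here, compound 3 thus holds the only number among the three values shown; the other two sit at a limit (the limit of > 50000 nM in this assay, at which 2 of the 3 values shown sit). The two measured steps that end at compound 3 are an at least 4.6-fold lower number from compound 1 to compound 3 (0.66 log units; beyond the scatter) and an at least 4.6-fold lower number from compound 2 to compound 3 (0.66 log units; beyond the scatter), each at least modest, and each exchanging a methoxycarbonyl-bearing chain for the 1-(hydroxymethyl)ethyl group. Compound 4 `CCn1c(C(=O)N[C@@H](CO)C(C)C)ccc1C(CC)(CC)c1ccc(OCS(=O)(=O)c2ccccc2)c(C)c1` has not yet been measured. It differs from compound 3 by 1-(hydroxymethyl)-2-methylpropyl in place of 1-(hydroxymethyl)ethyl on an amide-type nitrogen. No measured step touches this change: both steps shown concern the arrival of the hydroxymethyl-bearing group, not its enlargement, so they give no direction for lengthening the carbon branch while the hydroxymethyl and the amide stay in place. The account therefore expects no step beyond the scatter, a 1.1-fold lower number from compound 3 to compound 4 (0.03 log units; within the scatter), with a wider range than usual. Compound 4 is estimated at 10000 nM, between 3500 nM and 30000 nM.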

Compound 4, half-maximal inhibitory concentration: 18800 nM
The estimate for compound 4 lay 1.9-fold (0.27 log units) below the measured number; the range from low to high includes it.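

On the amide-type nitrogen, the 1-(hydroxymethyl)-2-methylpropyl group, larger than 1-(hydroxymethyl)ethyl, gives in this assay a 1.7-fold higher number from compound 3 to compound 4 (0.24 log units; within the scatter) so the added carbon branch does not move the number beyond the scatter. The gain over the ester-bearing chains therefore appears with a second hydroxymethyl-bearing group, with an at least 2.6-fold lower number from compound 2 to compound 4 (0.42 log units; beyond the scatter) and an at least 2.6-fold lower number from compound 1 to compound 4 (0.42 log units; beyond the scatter) alongside the steps already seen for compound 3. Compound 1 and compound 2 each sit at a limit of the assay and not at a number, so both sizes are bounds: the limit of > 50000 nM in this assay, at which 2 of the 4 values shown sit.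

Whether the hydroxyl itself is needed remains open, since a plain isobutyl group on this nitrogen is not among the compounds shown. Also open, on these data alone, are a carboxylic acid or an amine at the chain end, and the opposite configuration at the stereocentre.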